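This account rests on a few compounds, and the source may have more. Where it says the series, first, only, none or still open, it means among the compounds named here.

Compound 1 `CCn1c(C(=O)NCC#N)ccc1C(CC)(CC)c1ccc(OCCC(O)(CC)CC)c(C)c1` gives, in a functional assay on Caco-2 cells (Homo sapiens) for antiproliferative activity, read by MTT assay, with a stated time of 48 h (on this read-out lower numbers stand for stronger inhibition and higher numbers for weaker inhibition), only the assay limit > 50000 nM: compound 1 therefore sits at the limit of > 50000 nM in this assay, at which 1 of the 2 values shown sits, and no number is known for it. Compound 2 `CCn1c(C(=O)NCCN)ccc1C(CC)(CC)c1ccc(OCCC(O)(CC)CC)c(C)c1`, with aminomethyl in place of cyano, gives 1740 nM in this assay, the step of an at least 28-fold lower number from compound 1 to compound 2 (1.45 log units; beyond the scatter). Compound 3 `CCn1c(C(=O)NC(CC(=O)O)C(=O)OC)ccc1C(CC)(CC)c1ccc(OCCC(O)(CC)CC)c(C)c1` differs from compound 1 by a group of 9 heavy atoms (5 carbon, 4 oxygen; no ring) in place of a group of 3 heavy atoms (2 carbon, 1 nitrogen; no ring), on an amide-type nitrogen. Within the data shown here, no measured step carries this change, and the only large step seen here brought in aminomethyl rather than the group entering compound 3, so compound 3 is expected to stay near the limit, the step of an at least 1.2-fold lower number from compound 1 to compound 3 (0.09 log units; that floor lies within the scatter). Compound 3 is estimated at 40000 nM, between 8000 nM and 100000 nM.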

Compound 3, half-maximal inhibitory concentration: 25200 nM
Compound 3: the middle estimate sits 1.6-fold (0.20 log units) above what was measured; the range from low to high includes it.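

In this assay compound 3 gives 25200 nM, and the change on the amide-type nitrogen brings a 14-fold higher number from compound 2 to compound 3 (1.16 log units; beyond the scatter), so this larger group, with no ring, does not reach the level of compound 2. The comparison on the cyanomethyl side yields only an at least 1.9-fold lower number from compound 1 to compound 3 (0.29 log units; that floor lies within the scatter). Compound 1 holds a limit, not a number: the limit of > 50000 nM in this assay, at which 1 of the 3 values shown sits.

The compounds shown leave open which part of the entering group, the carboxylic acid or the methyl ester, governs the result. They also leave open whether a longer chain ending in an amine would differ from compound 2.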